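This account rests on a few compounds, and the source may have more. Where it says the series, first, only, none or still open, it means among the compounds named here.

Compound 1 `Nc1cccc(-c2cn3nc(-c4cccs4)sc3n2)c1` gives in a functional assay on FM3A cells (Mus musculus) for inhibition, read by cell counting, with a stated time of 2 days (a higher number here means a weaker inhibitor, a lower number a stronger inhibitor), only a limit, > 250000 nM. Compound 2 `C=C(Br)C(=O)Nc1cccc(-c2cn3nc(-c4ccc(F)cc4)sc3n2)c1` gives in this assay 610 nM. Compound 3 `COc1ccc(-c2nn3cc(-c4cccc(N)c4)nc3s2)cc1` gives in this assay 74000 nM.

Among the two numbers measured, compound 2 has the lowest. Its nearest neighbour is compound 3, whose higher number lies well beyond the usual scatter. For compound 1 the assay reports a limit, (the limit of > 250000 nM in this assay, at which 1 of the 3 values shown sits), and no number at all, so compound 1 is set aside here.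

Compound 4 `C=C(Br)C(=O)Nc1cccc(-c2cn3nc(-c4ccc(Cl)cc4)sc3n2)c1` has not yet been measured in this assay. It differs from compound 2 in a single place: chloro in place of fluoro on an aromatic carbon. For the measured compounds named here, no step between two measured compounds touches this change, so any expectation rests on compound 2 alone and on the nature of the change, chloro in place of fluoro on an aromatic carbon para to a large group. The step expected from compound 2 to compound 4 in this assay is a 1.0-fold lower number from compound 2 to compound 4 (0.01 log units; within the scatter), that is, none beyond the scatter in either direction. Compound 4 is accordingly estimated at 600 nM, with a range from 250 nM to 1500 nM.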

Compound 4, half-maximal inhibitory concentration: 2000 nM
Compound 4: middle estimate off by 3.3-fold (0.52 log units), on the low side, and the stated range ends below it.
By their numbers in this assay, from the lowest: compound 2; then compound 4; then compound 3. At a limit, above all of these: compound 1.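

In this assay, for the compounds shown here, the change from 4-fluorophenyl to 4-chlorophenyl gives a 3.3-fold higher number from compound 2 to compound 4 (0.52 log units; beyond the scatter), and this is the first change in a single place that can be read. It shows that this aromatic carbon, para to a large group, is not indifferent to which halogen it carries: one heavy atom replaces one heavy atom, no hydrogen-bond donor, acceptor or net charge enters or leaves, and the number still moves modestly beyond the scatter. Nothing shown here bears on why chloro gives the higher number.

The compounds shown leave open whether this trend with halogen size continues to bromo or iodo, and how a methyl, a nitrile or an amine would read at this position. They also leave open how a plain phenyl without any substituent would compare with compound 2 and compound 4.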